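Fluorinating the terminal phenyl of compound 1

The source may report more compounds than this note shows. Statements on the series, on what has been measured and on what is new or still open speak of the compounds shown alone.

Compound 1 `Cc1c(CCCC(=O)O)c2cccc(/C=C/c3ccc(OCCCCc4ccccc4)cc3)c2n1CC(=O)O` sits at a limit in a physicochemical assay for permeability, using PAMPA, with a stated time of 4 h, at pH 7.4, tested at 50 uM; a lower number here means that the compound crosses the layer more slowly, a higher number that the compound crosses the layer faster: compound 1 gives < 0.05 10^-6 cm/s, which is a limit of the assay and not a number (the limit of < 0.05 10^-6 cm/s in this assay, at which 1 of the 3 values shown sits). Compound 2 `Cc1c(Cl)cccc1CCCCOc1ccc(C#Cc2cccc3c(CCCC(=O)O)c(C)n(CCC(=O)O)c23)cc1` gives 3 10^-6 cm/s in this assay, and compound 3 `Cc1c(Cl)cccc1CCCCOc1ccc(C#Cc2cccc3c(CCCC(=O)O)c(C)n(CCCCC(=O)O)c23)cc1` gives 5 10^-6 cm/s. The step of a 1.7-fold higher number from compound 2 to compound 3 (0.22 log units; within the scatter) concerns the chain on the aromatic nitrogen and does not touch the change considered here. Compound 4 `Cc1c(CCCC(=O)O)c2cccc(/C=C/c3ccc(OCCCCc4c(F)ccc(F)c4F)cc3)c2n1CC(=O)O` differs from compound 1 by 2,3,6-trifluorophenyl in place of phenyl on a saturated chain carbon, four bonds along the chain from an oxygen on an aromatic ring. Going by the values given here, no measured step covers this change, so no shift beyond the scatter is expected from it. Compound 4 is therefore expected to remain near the limit shown by compound 1, estimated at 0.05 10^-6 cm/s with a range of 0.02 10^-6 cm/s to 0.3 10^-6 cm/s. The step of a number no lower from compound 1 to compound 4 (the limit leaves the size open) is expected accordingly.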

Compound 4, apparent permeability: 2.6 10^-6 cm/s
For compound 4 the middle estimate is 52-fold (1.72 log units) below the measured one; the measured number lies above the stated range.
By their numbers in this assay, from the lowest: compounds 4, 2 and 3 (each within the scatter of the next). At a limit, below all of these: compound 1.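

In this assay, this position, on a saturated chain carbon, four bonds along the chain from an oxygen on an aromatic ring, is not silent: 2,3,6-trifluorophenyl in place of phenyl gives an at least 52-fold higher number from compound 1 to compound 4 (1.71 log units; beyond the scatter). Going by these compounds alone, the only earlier step concerned the chain on the aromatic nitrogen, so this is the first reading at this position. The value of compound 1 is a limit and not a number, which leaves the full size of the step open: the limit of < 0.05 10^-6 cm/s in this assay, at which 1 of the 4 values shown sits.

As far as these compounds go, whether a monofluorophenyl or a pyridyl group in this place would give a similar step stays open. From the compounds shown here alone, the change is read on the core of compound 1 only, and whether it carries over to other cores is also open.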